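Closing an open chain into a five-membered ring

The compounds below may be only part of what the source reports. "The series", "measured", "known", "first", "only" and "open" are said of these compounds alone.

Measured so far in a functional assay on MCF7 cells (Homo sapiens) for antiproliferative activity; a lower number here means a stronger inhibitor of growth, a higher number a weaker inhibitor of growth:
- compound 1 `CC/C=C\[C@H](C)[C@H](OC(N)=O)[C@@H](C)[C@H](O)[C@@H](C)C/C(C)=C\[C@H](C)[C@@H](O)[C@@H](C)/C=C\[C@@H](O)C[C@H](O)[C@H](C)CO` gives (1000 nM)
- compound 2 `CC/C=C\[C@H](C)[C@H](OC(N)=O)[C@@H](C)[C@H](O)[C@@H](C)C/C(C)=C\[C@H](C)[C@@H](O)[C@@H](C)/C=C\[C@@H](O)C[C@@H]1OC(=O)NC[C@H]1C` gives (110 nM)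
- compound 3 `CC/C=C\[C@H](C)[C@H](OC(N)=O)[C@@H](C)[C@H](O)[C@@H](C)C/C(C)=C\[C@H](C)[C@@H](O)[C@@H](C)/C=C\[C@@H](O)C[C@@H]1OC(=O)[C@H](C)[C@@H](OC)[C@H]1C` gives (3.8 nM)

Compound 1 has the highest number of the three, so it is the weakest inhibitor of growth here. Compound 4 `CC/C=C\[C@H](C)[C@H](OC(N)=O)[C@@H](C)[C@H](O)[C@@H](C)C/C(C)=C\[C@H](C)[C@@H](O)[C@@H](C)/C=C\[C@H](O)C[C@@H]1CCC(=O)O1` differs from it in one place (a group of 9 heavy atoms (6 carbon, 3 oxygen; one five-membered non-aromatic ring with 1 hetero atom) in place of a group of 9 heavy atoms (6 carbon, 3 oxygen; no ring), on a double-bonded chain carbon bound to a double-bonded chain carbon). Two measured steps also replace the same open chain end with a ring: a 9.1-fold lower number from compound 1 to compound 2 (0.96 log units; beyond the scatter) is modest, and a 260-fold lower number from compound 1 to compound 3 (2.42 log units; beyond the scatter) is large. Among the compounds with values here, both of those rings are six-membered, and a 29-fold lower number from compound 2 to compound 3 (1.46 log units; beyond the scatter) shows how much rings can differ, so no measured compound shows what a five-membered ring does. A modest drop in this assay is therefore expected, closer to the first step than the second. The expected step is a 6.7-fold lower number from compound 1 to compound 4 (0.82 log units; beyond the scatter), though this remains uncertain. For compound 4 the estimate is 150 nM (range 30 nM to 700 nM).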

Compound 4, concentration for 50% growth inhibition: 2000 nM
Beside the measured number, compound 4's estimate is 13-fold (1.12 log units) below it, and the stated range ends below it.
By their numbers in this assay, from the lowest: compound 3; then compound 2; then compounds 1 and 4 (each within the scatter of the next).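

In this assay, the five-membered non-aromatic ring with 1 hetero atom gives a 2.0-fold higher number from compound 1 to compound 4 (0.30 log units; within the scatter) and so does not set compound 4 apart from the open chain of compound 1. Against the six-membered non-aromatic ring with 2 hetero atoms the result is an 18-fold higher number from compound 2 to compound 4 (1.26 log units; beyond the scatter) and this shows that closing a ring does not by itself bring a gain. Compound 4 thus goes against the trend that compounds 2 and 3 suggested.

Still open, as far as these compounds go, is what a five-membered ring carrying a methyl group or an amine would give. No measurement shown gives a cause for these differences.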